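Phenyl replaces isoxazolyl on the amide carbonyl

The source may hold more compounds than are shown below. What is called first, only, known or untested is meant among the compounds shown, and "the series" means these compounds.

Compound 1 `Cc1nc(C(=O)Nc2ccc(Cl)c(-c3nnc4c(Cl)cccn34)c2)cs1` in a functional assay on AN3-CA cells (Homo sapiens) for antiproliferative activity, read by MTT assay, with a stated time of 72 h (a lower number here means a stronger inhibitor, a higher number a weaker inhibitor), is reported as a limit, > 100000 nM.
Compound 2 `O=C(Nc1ccc(Cl)c(-c2nnc3c(Cl)cccn23)c1)c1ccc(Cl)cc1Cl` gives 84800 nM.
Compound 3 `O=C(Nc1ccc(Cl)c(-c2nnc3c(Cl)cccn23)c1)c1ccon1` is likewise reported as a limit, > 100000 nM.

Compound 3 thus stands at the limit rather than at a number, a point shared by two of the three values (the limit of > 100000 nM in this assay, at which 2 of the 3 values shown sit). Compound 4 `O=C(Nc1ccc(Cl)c(-c2nnc3c(Cl)cccn23)c1)c1ccccc1` differs from it by phenyl in place of 1,2-oxazol-3-yl on a carbonyl carbon. The closest measured step is an at least 1.1-fold higher number from compound 2 to compound 3 (0.07 log units; that floor lies within the scatter), while a step that the two limits leave unreadable from compound 1 to compound 3, so neither reading offers a usable anchor. Both point to very weak inhibition for compound 4 at best, with the change expected to give a number no higher from compound 3 to compound 4 (the limit leaves the size open), none beyond the scatter. Compound 4 is therefore estimated at 100000 nM, between 40000 nM and 250000 nM, most likely reported only as a limit.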

Compound 4, half-maximal inhibitory concentration: 67600 nM
For compound 4 the middle estimate is 1.5-fold (0.17 log units) above the measured one; low and high end bracket the measured number.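

With compound 4, phenyl joins the 2,4-dichlorophenyl of compound 2 in giving a number in this assay, while compound 1 and compound 3 remain limits: the limit of > 100000 nM in this assay, at which 2 of the 4 values shown sit. Against those limits, the readable floors are an at least 1.4-fold lower number from compound 3 to compound 4 (0.17 log units; that floor lies within the scatter) and an at least 1.4-fold lower number from compound 1 to compound 4 (0.17 log units; that floor lies within the scatter). The comparison with compound 2 gives a 1.3-fold lower number from compound 2 to compound 4 (0.10 log units; within the scatter), so the two chlorine atoms of the 2,4-dichlorophenyl make no readable difference here.

On these data alone, whether an amine or a carboxylic acid on the phenyl, or a longer chain on the carbonyl carbon, would move the number beyond the scatter stays open.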